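Ethyl in place of ethynyl on a lysophospholipid ether chain

This account rests on a few compounds, and the source may have more. Where it says the series, first, only, none or still open, it means among the compounds named here.

Measured compounds:
Compound 1, `CCCCCCCC/C=C\CCCCCCCC(=O)OC[C@@H](COC)OP(=O)(O)OC[C@H](N)C(=O)O`, gives "not active" (no number reported) in an assay on HEK293 cells for agonist activity at putative P2Y purinoceptor 10 (Mus musculus), with a stated time of 1 h; on this read-out lower numbers stand for smaller maximal responses and higher numbers for larger maximal responses.
Compound 2, `CCCCCCCC/C=C\CCCCCCCC(=O)OC[C@@H](COCC)OP(=O)(O)OC[C@H](N)C(=O)O`, gives "not active" (no number reported) in this assay.
Compound 3, `C#CCOC[C@H](COC(=O)CCCCCCC/C=C\CCCCCCCC)OP(=O)(O)OC[C@H](N)C(=O)O`, gives 3.2% in this assay.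

Three analogues of one serine-bearing phospholipid core have been examined so far. For compound 1 and compound 2 no number is reported at all; the maximal response of compound 3 is the only figure shown, and it stands at the very bottom of the scale, a response barely distinguishable from none. Compound 4, `CCCCCCCC/C=C\CCCCCCCC(=O)OC[C@@H](COCCC)OP(=O)(O)OC[C@H](N)C(=O)O`, remains to be measured. It differs from compound 3 in a single place: ethyl in place of ethynyl on a saturated chain carbon bound to an oxygen on a saturated carbon. The change replaces a triple bond by a saturated chain of the same length, with nothing else altered. Nothing among the three measured compounds suggests that this part of the molecule moves the response, and compound 3 sits close to the floor already. The step is therefore expected to lie within the scatter, and the estimated change in this assay is a number 0.2 percentage points lower from compound 3 to compound 4 (within the scatter). Compound 4 is expected to give 3%, with a range from 0% to 12%.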

Compound 4, largest response reached (Emax), in percent of the reference or control that the assay uses: "not active" (no number reported)
Compound 4 has no reported number here, so the estimate cannot be set against anything.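

For the compounds shown here, compound 4, like compound 1 and compound 2, has no number in this assay, so no step from compound 3 to compound 4 can be read. No evidence bears on this result. The compounds shown leave open whether exchanging ethynyl for ethyl changes the maximal response at all.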